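Ester to acid in a cyclopropylaminopurine glycinamide series

The compounds below may be only part of what the source reports. "The series", "measured", "known", "first", "only" and "open" are said of these compounds alone.

Measured in a functional assay on the whole organism (Tail, strain ICR) with Mus musculus as the target, in the tail flick test, with a stated time of 120 min, at a dose of 25 umol/kg by the oral route; a higher number here means a stronger effect of the compound at the dose given, a lower number a weaker effect: compound 1 `O=C(O)CNC(=O)CN(c1nc(Cl)nc2[nH]cnc12)C1CC1` gives 19.8%; compound 2 `C[C@@H](O)[C@H](NC(=O)CN(c1nc(Cl)nc2[nH]cnc12)C1CC1)C(=O)O` gives 37.6%; compound 3 `CSCC[C@H](NC(=O)CN(c1nc(Cl)nc2[nH]cnc12)C1CC1)C(=O)OCc1ccccc1` gives 31.6%.

Compound 3 stands second highest of the three numbers in this assay; its nearest neighbour is compound 2, a number higher only within the scatter, and its furthest is compound 1, lower by a margin beyond the scatter.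

Compound 4 `CSCC[C@H](NC(=O)CN(c1nc(Cl)nc2[nH]cnc12)C1CC1)C(=O)O` has not yet been measured. It differs from compound 3 as follows: hydrogen in place of benzyl on an oxygen next to a carbonyl group.

Among the compounds with values here, no measured step bears directly on this change. Within the data shown here, the one step known, a number 17.8 percentage points higher from compound 1 to compound 2 (beyond the scatter), concerns the chain carbon bound to the amide-type nitrogen and the carbonyl carbon, not the carboxy end. Compounds 1 and 2, which carry a carboxy group like compound 4, give values that bracket the number of compound 3. The direction of a step to compound 4 therefore cannot be read from the data, and no step beyond the scatter is expected: a number 1.6 percentage points lower from compound 3 to compound 4 (within the scatter) is the estimated change. Compound 4 is expected to give about 30% in this assay, with a range from 15% to 45%.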

Compound 4, a percentage reported as activity, at one dose (the size of the read-out at that dose, not a potency): 5.67%
Estimate against measurement, compound 4: 24.3 percentage points above; measured number below the stated range.
By their numbers in this assay, from the lowest: compound 4; then compound 1; then compounds 3 and 2 (each within the scatter of the next).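

In this assay, hydrogen in place of benzyl on an oxygen next to a carbonyl group gives a number 25.9 percentage points lower from compound 3 to compound 4 (beyond the scatter), so with 2-(methylsulfanyl)ethyl held fixed, the benzyloxycarbonyl form reads above the carboxy form. Among the carboxy compounds, 2-(methylsulfanyl)ethyl in place of hydrogen on the chain carbon gives a number 14.1 percentage points lower from compound 1 to compound 4 (beyond the scatter), and in place of 1-hydroxyethyl it gives a number 31.9 percentage points lower from compound 2 to compound 4 (beyond the scatter), which leaves compound 4 lowest of the series. Nothing at hand accounts for any of these steps.

On these data alone, whether benzyl on the same oxygen gives a step of like size with hydrogen or 1-hydroxyethyl on the chain carbon remains open. So does how a methyl ester or a primary amide in place of the carboxy group would read on the 2-(methylsulfanyl)ethyl compound.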